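Series notes: aryl cyclic hydrazides against 5-lipoxygenase

The compounds below may be only part of what the source reports. "The series", "measured", "known", "first", "only" and "open" are said of these compounds alone.

On these data alone, the series is small and rests on three measured compounds and one still open. Compound 1 `Cc1ccc(N2CCCC(=O)N2)cc1` and compound 2 `O=C1CCCN(c2ccc(Cl)cc2)N1` share one core, while compound 3 `Cc1ccccc1N1CCC(=O)N1` is built on a different core; how the core of compound 3 differs from the core of compound 1 is not broken down here. In an assay on isolated protein for inhibition of Polyunsaturated fatty acid 5-lipoxygenase (Homo sapiens) (on this read-out higher numbers stand for weaker inhibition and lower numbers for stronger inhibition), compound 1 gives 277000 nM, compound 2 gives 79000 nM and compound 3 gives 8200 nM, so compound 3 stands lowest of the three.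

One single change has been measured once. Compound 1 and compound 2 differ by chloro in place of methyl on an aromatic carbon, and this gave a 3.5-fold lower number from compound 1 to compound 2 (0.54 log units; beyond the scatter).

Compound 4 `O=C1CCN(c2ccccc2Cl)N1` is not yet measured. It differs from compound 3 by chloro in place of methyl on an aromatic carbon. Going by the values given here, this is the same kind of change as the one from compound 1 to compound 2, but not the same: in the measured pair the chloro sits para to a group of 7 heavy atoms, whereas in compound 4 it sits ortho to a group of 6 heavy atoms, and the cores also differ.

For compound 4 in this assay the expected step is a 2.7-fold lower number from compound 3 to compound 4 (0.44 log units; beyond the scatter), resting on the measured step from compound 1 to compound 2 of a 3.5-fold lower number from compound 1 to compound 2 (0.54 log units; beyond the scatter). The placement and the core differ, and that change has been measured only once; the expected step is kept smaller than the measured one. The estimate for compound 4 in this assay is therefore 3000 nM, with a plausible span from 1000 nM to 10000 nM.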

Compound 4, half-maximal inhibitory concentration: 3700 nM
Compound 4: middle estimate off by 1.2-fold (0.09 log units), on the low side, within the range that was stated.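

Working reading of the new pair: in this assay, chloro in place of methyl on the core of compound 3 gave a 2.2-fold lower number from compound 3 to compound 4 (0.35 log units; beyond the scatter), the same direction as the earlier step on the core of compound 1. Set side by side, the two steps cannot be told apart in size, which supports carrying this change between these two cores with about the same effect on the read-out: the same change on two cores in this assay, a 3.5-fold lower number (0.54 log units; beyond the scatter) from compound 1 to compound 2 and a 2.2-fold lower number (0.35 log units; beyond the scatter) from compound 3 to compound 4, 1.6-fold (0.20 log units) apart, within the scatter of two such steps

Going by these compounds alone, this agreement rests on only two pairs, and those pairs differ in the placement of the chloro as well as in the core, so it does not separate the contribution of either difference or show that the step would hold on any further core.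

The compounds shown leave open what the core alone contributes, as the two cores appear here only with differently placed groups on the aromatic ring. Also open, on these data alone, is how a group other than methyl or chloro, such as a methoxy, a nitrile, an amine or a carboxylic acid, would behave on the aromatic ring of either core.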